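Butyl extension of the saturated chain from compound 2 to compound 3

The source may hold more compounds than are shown below. What is called first, only, known or untested is meant among the compounds shown, and "the series" means these compounds.

Measured so far in a functional assay on a cell-free system (plasma) for inhibition of platelet-activating factor acetylhydrolase (Homo sapiens), tested at 100 nM; on this read-out lower numbers stand for less inhibition and higher numbers for more inhibition at the one concentration tested (going by the name of the read-out):
Compound 1 `CCCCCCCCN(C)C(=O)Cn1cc(Cc2cnc(OCC)nc2)c(=O)nc1SCc1ccc(F)cc1`: 23%
Compound 2 `CCCCCCCCN(C)C(=O)Cn1cc(Cc2cnc(O)nc2)c(=O)nc1SCc1ccc(F)cc1`: 66%

Compound 2 holds the higher of the two numbers; the step of a number 43 percentage points higher from compound 1 to compound 2 (beyond the scatter) lies beyond the scatter and concerns a hydrogen in place of ethyl on an oxygen on an aromatic ring.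

Compound 3 `CCCCCCCCCCCCN(C)C(=O)Cn1cc(Cc2cnc(O)nc2)c(=O)nc1SCc1ccc(F)cc1` is not yet measured. Its difference from compound 2 is butyl in place of hydrogen on a saturated chain carbon, eight bonds along the chain from an amide-type nitrogen. Going by the values given here, no measured step touches this place: the one step in hand changes the group on the aromatic oxygen, not the saturated chain, so nothing in the data bears on the butyl change. Among the compounds with values here, with no guidance from measured steps, the working expectation is a step of no more than the usual scatter, in either direction, so that the estimated step of a number 1 percentage points lower from compound 2 to compound 3 (within the scatter) is small. Compound 3 is therefore expected to give about 65% in this assay, within the range 40% to 85%.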

Compound 3, a percentage reported as inhibition, at one concentration (the size of the read-out at that concentration, not a potency): 83%
Beside the measured number, compound 3's estimate is 18 percentage points below it; the range from low to high includes it.
By their numbers in this assay, from the lowest: compound 1; then compound 2; then compound 3.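

In this assay there is a number 17 percentage points higher from compound 2 to compound 3 (beyond the scatter) when butyl replaces hydrogen on a saturated chain carbon, eight bonds along the chain from an amide-type nitrogen. The saturated chain is therefore a second place in the series where the read-out moves beyond the scatter, alongside the group on the aromatic oxygen, and the added butyl raises the number rather than lowering it. Nothing measured here accounts for this step.

On these data alone, a single extension defines no trend, so it remains open whether an ethyl extension or a longer chain than that of compound 3 would raise or lower the number. Also open, as far as these compounds go, are whether an amine or a carboxylic acid on the same chain would raise, lower or leave level the number and whether the butyl step would recur with ethyl on the aromatic oxygen.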